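The source may hold more compounds than are shown below. What is called first, only, known or untested is meant among the compounds shown, and "the series" means these compounds.

Measured compounds:
compound 1 `CCOc1ccccc1-c1ccc(-c2nc3cnccc3c(N[C@H](CC)C(N)=O)c2C#N)cc1` — 3
compound 2 `CCOc1ccccc1-c1ccc(-c2nc3cnccc3c(NC(C)C(=O)O)c2C#N)cc1` — 2.1

In a physicochemical assay for lipophilicity, read by HPLC, at pH 7.5 (on this read-out higher numbers stand for higher lipophilicity and lower numbers for lower lipophilicity), compound 2 gives 2.1, the lowest of the two numbers; compound 1 gives 3. Compound 3 `CCOc1ccccc1-c1ccc(-c2nc3cnccc3c(N[C@H](CC)C(=O)NS(C)(=O)=O)c2C#N)cc1` has not yet been measured. The change from compound 2 to compound 3 is a group of 10 heavy atoms (5 carbon, 1 nitrogen, 3 oxygen, 1 sulfur; no ring) in place of a group of 5 heavy atoms (3 carbon, 2 oxygen; no ring), on a nitrogen on an aromatic ring. For the measured compounds named here, the only measured step, a number 0.90 log units lower from compound 1 to compound 2 (beyond the scatter), concerns a different exchange and bears on this one only loosely. Going by the values given here, the sole comparison available, compound 1 against compound 2, suggests a modest rise is expected: a number 0.50 log units higher from compound 2 to compound 3 (beyond the scatter). Compound 3 is therefore estimated at 2.6, between 2 and 3.2.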

Compound 3, distribution coefficient: 2.2
For compound 3 the middle estimate is 0.40 log units above the measured one, and the stated range covers the measured number.
By their numbers in this assay, from the lowest: compounds 2 and 3 (each within the scatter of the next); then compound 1.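

On the amide-type nitrogen, methylsulfonyl in place of hydrogen gives a number 0.80 log units lower from compound 1 to compound 3 (beyond the scatter) in this assay. Exchanging 1-carboxyethyl for the larger group on the nitrogen on the aromatic ring gives a number 0.10 log units higher from compound 2 to compound 3 (within the scatter), so a group with more heavy atoms and more hydrogen-bond acceptors still leaves compound 3 level with compound 2 on this read-out. Nothing available accounts for either step. The compounds shown leave open how 1-carboxypropyl would read at this position, since it would separate the acid from the chain length. They also leave open how phenylsulfonyl would read on the amide-type nitrogen.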